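Swapping phenyl for pyridin-4-yl on a pyranopyrazole core

The compounds below may be only part of what the source reports. "The series", "measured", "known", "first", "only" and "open" are said of these compounds alone.

The measured compounds are compound 1 `Cc1nn(C)c2c1C(c1ccccc1)C(C#N)=C(N)O2` with 9100 nM, compound 2 `Cc1nn(C)c2c1C(c1ccc(OC(F)(F)F)cc1)C(C#N)=C(N)O2` with 2900 nM, and compound 3 `Cc1nn(C)c2c1C(c1ccc(C#N)cc1)C(C#N)=C(N)O2` with 5600 nM, all in a functional assay on NCI-H2122 cells (Homo sapiens) for inhibition, read by microscopy, with a stated time of 10 days; a higher number here means a weaker inhibitor, a lower number a stronger inhibitor.

Compound 1 gives the highest number of the three in this assay. Its two neighbours carry a substituent on the phenyl ring: a 3.1-fold lower number from compound 1 to compound 2 (0.50 log units; beyond the scatter), and a 1.6-fold lower number from compound 1 to compound 3 (0.21 log units; within the scatter). Compound 4 `Cc1nn(C)c2c1C(c1ccncc1)C(C#N)=C(N)O2` takes a different path: pyridin-4-yl in place of phenyl on a saturated ring carbon. Neither measured step replaces the ring itself, so they bear only loosely on compound 4; the step beyond the scatter came from adding a group, not from changing the ring atoms. The expectation is therefore a step within the scatter, with no clear direction: a 1.0-fold lower number from compound 1 to compound 4 (0.00 log units; within the scatter). Compound 4 is estimated at 9000 nM, expected between 4000 nM and 20000 nM.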

Compound 4, half-maximal inhibitory concentration: 4100 nM
Compound 4: the middle estimate sits 2.2-fold (0.34 log units) above what was measured; measured number inside the range.
By their numbers in this assay, from the lowest: compounds 2, 4, 3 and 1 (each within the scatter of the next, the first and the last beyond it).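

At this saturated ring carbon, the ring itself can be changed with a measurable result: in this assay, there is a 2.2-fold lower number from compound 1 to compound 4 (0.35 log units; beyond the scatter). Until now, only added substituents on the phenyl ring had given a step beyond the scatter, whereas here the group keeps its heavy-atom count and exchanges one ring carbon for nitrogen, gaining a hydrogen-bond acceptor. Nothing available explains this step.

The compounds shown leave open whether a second ring nitrogen, as in a pyrimidine, would move the number further. They also leave open how an amine on the pyridin-4-yl ring would read.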